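A few compounds are considered here, and "the series" means these few. Any claim that something is new, unique, unknown or untested is made for them only; others in the source may bear on it.

The compounds here share one core, seen in compound 1 `COc1ccc(/C=C\C(=O)O)c(OCc2cn(-c3ccc(NC(=O)c4ccccc4)cc3)nn2)c1CC=C(C)C`, compound 3 `COc1ccc(/C=C\C(=O)O)c(OCc2cn(-c3ccccc3C(=O)N3CCC(O)C3)nn2)c1CC=C(C)C` and compound 2 `COc1ccc(-n2cc(COc3c(/C=C\C(=O)O)ccc(OC)c3CC=C(C)C)nn2)cc1`, and differ only in the ring attached to the aromatic nitrogen of the five-membered ring. In a functional assay on COLO 205 cells (Homo sapiens) for cytotoxicity, read by MTT assay, with a stated time of 24 h (a higher number here means a weaker inhibitor, a lower number a stronger inhibitor), compound 1 gives 20300 nM, and in this assay compound 3 gives 25400 nM; these two values lie close together, so nothing separates them beyond the usual scatter. For compound 2 the entry in this assay reads "not determined" (no result reported), so it stands without a number of its own, and its place can only be judged from the neighbours that were measured.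

Compound 4 `COc1ccc(/C=C\C(=O)O)c(OCc2cn(-c3cccc([N+](=O)[O-])c3)nn2)c1CC=C(C)C` is the next step: 3-nitrophenyl in place of 4-methoxyphenyl on an aromatic nitrogen. Among the measured compounds shown here, since compound 2 itself has no value, no step from it to compound 4 can be sized; the only guide is that compound 1 and compound 3, which carry quite different rings at the same place, both sit in the same weak range. The expectation is therefore that the change to 3-nitrophenyl moves the number little, if at all, beyond the scatter, with no clear direction. On that basis compound 4 is estimated at 22000 nM, within a range from 7000 nM to 70000 nM.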

Compound 4, half-maximal inhibitory concentration: 6900 nM
Compound 4: the middle estimate sits 3.2-fold (0.50 log units) above what was measured; the measured number lies below the stated range.
By their numbers in this assay, from the lowest: compound 4; then compounds 1 and 3 (each within the scatter of the next).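

Among the compounds shown here, compound 2 has no number in this assay, and no step from it to compound 4 can be read. No measurement shown gives a reason for the result of compound 4. The compounds shown leave open how 3-nitrophenyl and 4-methoxyphenyl compare directly when attached at this place on the shared core.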